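Three Relatives at the Limit, a Fourth Expected There

The source may hold more compounds than are shown below. What is called first, only, known or untested is meant among the compounds shown, and "the series" means these compounds.

Compound 2 `CCOc1ccccc1-n1nncc1CN1C(=O)C2(C(C#N)=C(N)Oc3c2c2nc4ccccc4nc2c2ccccc32)c2ccccc21` is one of three close relatives tested in an ADME assay on L02 cells (Homo sapiens) for antiproliferative activity, read by MTT assay, with a stated time of 48 h; a higher number here means a weaker inhibitor, a lower number a stronger inhibitor. In this assay compound 2 gives > 50000 nM, which is a limit of the assay rather than a number. Compound 1 `N#CC1=C(N)Oc2c(c3nc4ccccc4nc3c3ccccc23)C12C(=O)N(Cc1cnnn1-c1ccccc1Cl)c1ccccc12` carries a 2-chlorophenyl group where compound 2 carries 2-ethoxyphenyl. In this assay compound 1 gives > 50000 nM, again a limit. Compound 3 `Cc1ccc(-n2nncc2CN2C(=O)C3(C(C#N)=C(N)Oc4c3c3nc5ccccc5nc3c3ccccc43)c3ccccc32)c(C)c1` carries a 2,4-dimethylphenyl group on the same aromatic nitrogen. In this assay compound 3 gives > 50000 nM, also a limit. Because (the limit of > 50000 nM in this assay, at which 3 of the 3 values shown sit), the steps a step that the two limits leave unreadable from compound 1 to compound 2, a step that the two limits leave unreadable from compound 1 to compound 3 and a step that the two limits leave unreadable from compound 2 to compound 3 cannot be sized; none of the three exchanges of the aryl group on that nitrogen produced a readable number.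

Compound 4 `N#CC1=C(N)Oc2c(c3nc4ccccc4nc3c3ccccc23)C12C(=O)N(Cc1cnnn1-c1ccc(F)c(Cl)c1)c1ccccc12` is a further variant of this kind: 3-chloro-4-fluorophenyl in place of 2-ethoxyphenyl on an aromatic nitrogen. For the measured compounds named here, the change again exchanges the aryl group on that aromatic nitrogen, exactly the place where all three measured steps were unreadable, so no measured step gives a direction or a size to expect in this assay. The expectation is therefore that compound 4 will also sit at the limit. Compound 4 is expected to give about 60000 nM in this assay, within a range from 30000 nM to 150000 nM. That estimate means an expected step that the limit leaves unreadable from compound 2 to compound 4, which is not readable beyond the limit either.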

Compound 4, half-maximal inhibitory concentration: > 50000 nM
Compound 4 gave a limit, no number (the forecaster's own chance of this, stated with the estimate: 85%); the middle value is on the limit's open side.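

In this assay compound 4 gives > 50000 nM as a limit, not a number. Its steps from compound 1, compound 2 and compound 3 therefore cannot be read: the limit of > 50000 nM in this assay, at which 4 of the 4 values shown sit. The compounds shown leave open whether any aryl group on that aromatic nitrogen would give a readable number in this assay at all.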